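A Longer Straight Chain on the Amide Nitrogen

The compounds below may be only part of what the source reports. "The series", "measured", "known", "first", "only" and "open" are said of these compounds alone.

Three compounds share one core and differ only in the group carried by the amide nitrogen. Compound 1 `COc1cc2c(cc1OC)C(CC(=O)N(C)C)CC2` gives 23.3% in a functional assay on the whole organism (strain Wistar) for inhibition, with Rattus norvegicus as the target, read by paw edema, with stated times of 60 min and 24 h, at a dose of 100 mg/kg by the oral route; a lower number here means less inhibition, a higher number more inhibition at the dose given (going by the name of the read-out). Compound 2 `CCCNC(=O)CC1CCc2cc(OC)c(OC)cc21` gives 26.7%, and compound 3 `COc1cc2c(cc1OC)C(CC(=O)NC(C)(C)C)CC2` gives 40%. Compound 3 stands highest of the three, and its lead over both others is beyond the scatter: a number 13.3 percentage points higher from compound 2 to compound 3 (beyond the scatter) and a number 16.7 percentage points higher from compound 1 to compound 3 (beyond the scatter). By contrast the move a number 3.4 percentage points higher from compound 1 to compound 2 (within the scatter) was small and within the scatter.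

Compound 4 `CCCCCNC(=O)CC1CCc2cc(OC)c(OC)cc21` has not yet been measured. Its change from compound 3 is pentyl in place of tert-butyl on an amide-type nitrogen, so (tert-butyl)amino becomes pentylamino. Going by the values given here, two steps bear on this. The step of a number 13.3 percentage points higher from compound 2 to compound 3 (beyond the scatter) shows that putting tert-butyl in place of a straight propyl chain gave a modest rise, and the step of a number 3.4 percentage points higher from compound 1 to compound 2 (within the scatter) shows that a straight chain in place of dimethylamino changed little. Going back to a straight chain, now pentyl, is therefore expected to undo part of that rise, as a step of a number 10 percentage points lower from compound 3 to compound 4 (within the scatter). Compound 4 is estimated at 30%, with a range from 18% to 42%.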

Compound 4, a percentage reported as inhibition, in the whole organism at one dose (the size of the read-out at that dose, not a potency): 46.7%
Compound 4: the middle estimate sits 16.7 percentage points below what was measured; the measured number lies above the stated range.
By their numbers in this assay, from the lowest: compounds 1 and 2 (each within the scatter of the next); then compounds 3 and 4 (each within the scatter of the next).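

A straight chain on the amide nitrogen does not by itself hold the number down: going from propyl to pentyl gives a number 20 percentage points higher from compound 2 to compound 4 (beyond the scatter) and pentylamino in place of dimethylamino gives a number 23.4 percentage points higher from compound 1 to compound 4 (beyond the scatter) at this same position. Pentyl in place of tert-butyl gives a number 6.7 percentage points higher from compound 3 to compound 4 (within the scatter) and so leaves the two groups indistinguishable here, which shows that a tert-butyl branch is not needed to reach this higher range among these compounds. No measurement shown explains why these groups differ in this way.

As far as these compounds go, it remains open whether a longer chain such as heptyl would raise the number further or leave it level. Also open, from the compounds shown here alone, is how a cyclohexyl ring, or an amine or carboxylic acid at the end of the chain, would compare with pentyl at this nitrogen.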